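This account rests on a few compounds, and the source may have more. Where it says the series, first, only, none or still open, it means among the compounds named here.

Compound 1 `COc1cc(-c2nnc3n2NC(c2ccco2)C(C(=O)c2cccs2)S3)cc(OC)c1OC` gives 64100 nM in a functional assay on HepG2 cells (Homo sapiens) for cytotoxicity, read by MTT assay, with a stated time of 48 h; on this read-out higher numbers stand for weaker inhibition and lower numbers for stronger inhibition.
Compound 2 `COc1cc(-c2nnc3n2NC(c2cccs2)C(C(=O)c2ccc(Cl)cc2)S3)cc(OC)c1OC` gives 13200 nM in this assay.

Only these two compounds have been measured. Compound 2 stands at the lowest of the two numbers, and its nearest neighbour, compound 1, sits at a higher number by a gap that is beyond the usual scatter. Within the data shown here, compound 1 and compound 2 differ in more than one place, so the two values show only that compound 2 is the stronger of the pair, not which part of the change is responsible.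

Compound 3 `COc1cc(-c2nnc3n2NC(c2ccco2)C(C(=O)c2ccc(Cl)cc2)S3)cc(OC)c1OC` has not yet been measured. It differs from compound 2 in one place: furan-2-yl in place of thiophen-2-yl on a saturated ring carbon. Among the measured compounds shown here, no measured step of this single change is available. Because compound 1, which also carries furan-2-yl, gives 64100 nM, a modest move toward a higher number is expected for compound 3, though the direction is uncertain since compound 1 also differs at the carbonyl group. The step from compound 2 to compound 3 is expected to be a 1.9-fold higher number from compound 2 to compound 3 (0.28 log units; within the scatter). Compound 3 is therefore estimated at 25000 nM, with a range from 8000 nM to 80000 nM.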

Compound 3, half-maximal inhibitory concentration: 78600 nM
Estimate against measurement, compound 3: 3.1-fold (0.50 log units) below, within the range that was stated.
By their numbers in this assay, from the lowest: compound 2; then compounds 1 and 3 (each within the scatter of the next).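

In this assay, with the (4-chlorophenyl)carbonyl group held constant, furan-2-yl in place of thiophen-2-yl on the saturated ring carbon gives a 6.0-fold higher number from compound 2 to compound 3 (0.77 log units; beyond the scatter), so this position distinguishes between two groups that have the same heavy-atom count and differ only in the ring hetero atom. Among these compounds, with furan-2-yl held constant on that carbon, 4-chlorophenyl in place of thiophen-2-yl on the carbonyl carbon gives a 1.2-fold higher number from compound 1 to compound 3 (0.09 log units; within the scatter), which lies within the scatter, so the two single changes now come apart in a way the first pair of compounds could not show: only the change on the saturated ring carbon produces a step beyond the scatter. Nothing available accounts for the difference between furan-2-yl and thiophen-2-yl at this position.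

Among the compounds shown here, whether the carbonyl exchange stays as flat with thiophen-2-yl on the saturated ring carbon remains open, since the only reading of it carries furan-2-yl there. Also open, as far as these compounds go, is how that carbon would respond to a group outside this pair of five-membered rings, such as a phenyl ring, a methyl group or an aminomethyl chain.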